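Dropping a Chloro Group: Expected Cytotoxicity of Compound 4

This account rests on a few compounds, and the source may have more. Where it says the series, first, only, none or still open, it means among the compounds named here.

Of the compounds shown here, three have been tested in an ADME assay on MDCK cells (Canis lupus familiaris) for cytotoxicity, read by CellTiter-Glo, with a stated time of 40 h; on this read-out lower numbers stand for higher toxicity in this test and higher numbers for lower toxicity in this test. Compound 1 `CCCc1c(Cl)c(O)c(Cl)c(OC)c1Oc1c(Cl)c(O)c(Cl)c2c1C(=O)O[C@@H]2CC` gives only a limit of the assay, > 100000 nM. Compound 2 `CCCc1c(Cl)c(O)cc(O)c1Oc1c(Cl)c(O)c(Cl)c2c1C(=O)O[C@@H]2CC` likewise gives only a limit, > 50000 nM. Compound 3 `CCCc1cc(O)c(Cl)c(O)c1Oc1c(Cl)c(O)c(Cl)c2c1C(=O)O[C@@H]2CC` also returns a limit rather than a number, > 100000 nM. Compound 3 therefore stands where no cytotoxicity was resolved, and since all three results are limits, no order among compound 1, compound 2 and compound 3 can be drawn; the results fall at the limit of > 100000 nM in this assay, at which 2 of the 3 values shown sit, and at the limit of > 50000 nM in this assay, at which 1 of the 3 values shown sits.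

Compound 4 `CCCc1cc(O)cc(O)c1Oc1c(Cl)c(O)c(Cl)c2c1C(=O)O[C@@H]2CC` has not yet been measured. It differs from compound 3 by hydrogen in place of chloro on an aromatic carbon. Within the data shown here, no measured pair in this set follows a change of this kind, so the step can only be judged from the compounds at hand, none of which shows resolvable toxicity in this assay. The expected step is a number no higher from compound 3 to compound 4 (the limit leaves the size open), that is, none beyond the scatter. Compound 4 is accordingly estimated at 100000 nM in this assay, with a range from 50000 nM to 300000 nM, and the result is most likely to be reported once more as a limit.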

Compound 4, half-maximal cytotoxic concentration: > 100000 nM
Compound 4: no number, only a limit; the forecaster's own chance of this, stated with the estimate: 85%; the middle value lies on the limit itself.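

In this assay compound 4 again gives only a limit, > 100000 nM. Compound 2 and compound 3 also stand as limits, so neither step to compound 4 can be read. The compounds shown leave open whether hydrogen in place of chloro changes the read-out at all, and most of the results share one limit: the limit of > 100000 nM in this assay, at which 3 of the 4 values shown sit.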